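Methoxy in place of trifluoromethyl, expected size of step

The compounds below may be only part of what the source reports. "The series", "measured", "known", "first", "only" and "open" are said of these compounds alone.

Two compounds have numbers in a functional assay on U-251 cells (Homo sapiens) for inhibition, read by sulforhodamine B assay, with a stated time of 48 h; a higher number here means a weaker inhibitor of growth, a lower number a stronger inhibitor of growth. Compound 1 `COc1ccc(C2CC(=O)C(I)=CO2)cc1` gives 24.4 uM in this assay. Compound 2 `O=C1C=CCC(/C=C/c2ccc(C(F)(F)F)cc2)O1` gives 36.8 uM in this assay; this is the higher of the two numbers, and compound 1 stands nearest, within the scatter, so no order between the two is claimed. Compound 3 `COc1ccc(/C=C/C2CC=CC(=O)O2)cc1` is not yet measured in this assay. The change from compound 2 to compound 3 is methoxy in place of trifluoromethyl on an aromatic carbon. Going by the values given here, no pair of measured compounds differing in one place is available, so no measured step guides the size of this change. Compound 1 carries a methoxy on its aromatic ring and sits within the scatter of compound 2, and on that basis the step from compound 2 to compound 3 in this assay is expected to be a 1.2-fold lower number from compound 2 to compound 3 (0.09 log units; within the scatter), none beyond the scatter. Compound 3 is therefore expected at 30 uM, with a range from 10 uM to 90 uM.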

Compound 3, concentration for growth inhibition (reported as GI): 20.6 uM
Compound 3: the middle estimate sits 1.5-fold (0.16 log units) above what was measured; the range from low to high includes it.
By their numbers in this assay, from the lowest: compounds 3, 1 and 2 (each within the scatter of the next).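

Methoxy in place of trifluoromethyl, on an aromatic carbon of a six-membered aromatic ring of carbon only, para to a group of 9 heavy atoms, gives the first single-place step in the series: in this assay it is a 1.8-fold lower number from compound 2 to compound 3 (0.25 log units; within the scatter) and stays inside the usual variation between repeats. At this position, therefore, the two groups are not separated in this assay, even though methoxy carries a hydrogen-bond acceptor and trifluoromethyl carries none. No measurement bears on what underlies this result.

The compounds shown leave open whether an amine, a carboxylic acid or a longer chain such as ethoxy at this aromatic carbon would give a step beyond the scatter. Going by these compounds alone, compound 1 differs from compound 3 in more than one place, so no step between them can be read.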